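Adding a Second Fluorine to a Phenyl Substituent

A few compounds are considered here, and "the series" means these few. Any claim that something is new, unique, unknown or untested is made for them only; others in the source may bear on it.

Measured compounds:
Compound 1, `COc1cc2c(Oc3ccc(NC(=O)c4nccc(-c5ccccc5)n4)cc3F)ccnc2cc1OCCCN1CCCCC1`: "not determined" (no result reported)
Compound 2, `COc1cc2c(Oc3ccc(NC(=O)c4nccc(-c5ccc(C)cc5)n4)cc3F)ccnc2cc1OCCCN1CCCCC1`: 1140 nM
Compound 3, `COc1cc2c(Oc3ccc(NC(=O)c4nccc(-c5ccc(F)cc5)n4)cc3F)ccnc2cc1OCCCN1CCCCC1`: "not determined" (no result reported)

In a functional assay on U-87MG ATCC cells (Homo sapiens) for cytotoxicity, read by MTT assay, with a stated time of 72 h (on this read-out lower numbers stand for stronger inhibition and higher numbers for weaker inhibition), compound 2 gives 1140 nM. For compound 1 the result is "not determined" (no result reported), and for compound 3 it is "not determined" (no result reported), so compound 3 stands without any number of its own and the only measured anchor among the three is compound 2. Compound 4, `COc1cc2c(Oc3ccc(NC(=O)c4nccc(-c5ccc(F)cc5F)n4)cc3F)ccnc2cc1OCCCN1CCCCC1`, differs from compound 3 by fluoro in place of hydrogen on an aromatic carbon, a fluoro in place of hydrogen on an aromatic carbon. Going by the values given here, with no measured pair showing this change, the step from compound 3 to compound 4 in this assay is expected to stay within the usual scatter, in no clear direction. Compound 4 is therefore estimated near the value of compound 2, at 1100 nM, expected to lie between 300 nM and 4000 nM.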

Compound 4, half-maximal inhibitory concentration: 780 nM
For compound 4 the middle estimate is 1.4-fold (0.15 log units) above the measured one, and the stated range covers the measured number.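

Going by these compounds alone, compound 4 puts a first number on a fluorinated phenyl group at this position: this assay shows a 1.5-fold lower number from compound 2 to compound 4 (0.16 log units; within the scatter) and so does not separate 2,4-difluorophenyl from 4-methylphenyl. The effect of the added fluoro alone cannot be read, as compound 3 and compound 1 have no number. Nothing measured here offers an explanation for this result. Still open, going by these compounds, is whether an amine or a methoxy group on this phenyl ring would move the number beyond the scatter.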